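From Isobutyl to Cyclopentylmethyl on a Shared Core

The source may report more compounds than this note shows. Statements on the series, on what has been measured and on what is new or still open speak of the compounds shown alone.

Of the compounds shown here, three sharing one core have been measured in a functional assay on HL-60 cells (Homo sapiens) for inhibition; on this read-out higher numbers stand for weaker inhibition and lower numbers for stronger inhibition. Compound 1 `COc1ccc(-c2cc(=O)n(CC(C)C)nc2-c2ccc(OC)cc2)cc1`, which carries isobutyl on an aromatic nitrogen, gives > 100000 nM, and this is a limit of the assay, not a number. It therefore stands at the limit of > 100000 nM in this assay, at which 1 of the 3 values shown sits. Compound 2 `COc1ccc(-c2cc(=O)n(C(C)C)nc2-c2ccc(OC)cc2)cc1` gives 1320 nM, and compound 3 `COc1ccc(-c2cc(=O)n(C)nc2-c2ccc(OC)cc2)cc1` gives 1130 nM. Compound 4 `COc1ccc(-c2cc(=O)n(CC3CCCC3)nc2-c2ccc(OC)cc2)cc1` keeps the core of compound 1 but has cyclopentyl in place of isopropyl on a saturated chain carbon bound to an aromatic nitrogen. The same difference reads isobutyl to cyclopentylmethyl.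

Within the data shown here, two measured steps bear on this change: an at least 75-fold lower number from compound 1 to compound 2 (1.87 log units; beyond the scatter) and an at least 88-fold lower number from compound 1 to compound 3 (1.94 log units; beyond the scatter). Both are large, and in both the isobutyl group is lost. The step of a 1.2-fold lower number from compound 2 to compound 3 (0.07 log units; within the scatter) shows no separation between those two replacements. Among the measured compounds shown here, compound 4 does not lose that saturated chain carbon with its ring-bearing branch, so it stays closer to compound 1, and no measured compound carries cyclopentyl. Only a modest step is therefore expected, towards a lower number if any can be seen, and compound 4 may also reach the limit. The expected change is an at least 2.0-fold lower number from compound 1 to compound 4 (0.30 log units; that floor lies within the scatter). The estimate for compound 4 is 50000 nM, with an expected range from 3000 nM to 100000 nM.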

Compound 4, half-maximal inhibitory concentration: 110 nM
Compound 4: middle estimate off by 450-fold (2.66 log units), on the high side; measured number outside the range, below it.
By their numbers in this assay, from the lowest: compound 4; then compounds 3 and 2 (each within the scatter of the next). At a limit, above all of these: compound 1.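

Going from isobutyl to cyclopentylmethyl in this assay gives an at least 900-fold lower number from compound 1 to compound 4 (2.95 log units; beyond the scatter), so keeping a saturated chain carbon bound to the aromatic nitrogen does not by itself bring the loss seen with compound 1. Cyclopentylmethyl also improves on the two groups that had seemed the best tolerated here, with a 10-fold lower number from compound 3 to compound 4 (1.01 log units; beyond the scatter) and a 12-fold lower number from compound 2 to compound 4 (1.08 log units; beyond the scatter), which places the lowest number of the four on the only group that carries a ring and shows that the position can give more than methyl and isopropyl did. The read-out does not follow group size across these compounds, and compound 1 goes against any such trend, while its own entry is a limit and not a number: the limit of > 100000 nM in this assay, at which 1 of the 4 values shown sits.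

The compounds shown leave open whether the gain needs the five-membered ring itself, or whether cyclobutylmethyl, cyclohexylmethyl or benzyl on the same nitrogen would serve as well. They also leave open how a ring holding an ether oxygen or an amine would read here, and why isobutyl and cyclopentylmethyl lie so far apart.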